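The compounds below may be only part of what the source reports. "The series", "measured", "known", "first", "only" and "open" are said of these compounds alone.

Compound 1 `FC(F)(F)c1ccc(CSc2nc(Sc3ccccn3)cc(C(F)(F)F)n2)cc1` gives 23900 nM in a functional assay on NCI-H1975 cells (Homo sapiens) for inhibition, read by MTT assay, with a stated time of 72 h; on this read-out lower numbers stand for stronger inhibition and higher numbers for weaker inhibition.
Compound 2 `FC(F)(F)c1ccc(CSc2nc(Sc3nncs3)cc(C(F)(F)F)n2)cc1` gives 2270 nM in this assay.

Compound 2 holds the lowest of the two numbers; its nearest neighbour is compound 1, separated by the step of an 11-fold lower number from compound 1 to compound 2 (1.02 log units; beyond the scatter). That single step shows that exchanging the heteroaryl on this sulfur can move the read-out a long way.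

Compound 3 `FC(F)(F)c1ccc(CSc2nc(Sc3ncc(-c4ccncc4)s3)cc(C(F)(F)F)n2)cc1` has not yet been measured. The change is 5-(pyridin-4-yl)-1,3-thiazol-2-yl in place of 1,3,4-thiadiazol-2-yl on a sulfur. Among the compounds with values here, no measured step exchanges a 1,3,4-thiadiazol-2-yl for a 5-(pyridin-4-yl)-1,3-thiazol-2-yl, so only the size, not the direction, of the earlier step bears on it. For compound 3 a step of about a 1.5-fold lower number from compound 2 to compound 3 (0.18 log units; within the scatter) is therefore expected, and with wide uncertainty. Compound 3 is estimated at 1500 nM in this assay, within a range of 400 nM to 6000 nM.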

Compound 3, half-maximal inhibitory concentration: 16700 nM
The estimate for compound 3 lay 11-fold (1.05 log units) below the measured number; measured number above the stated range.
By their numbers in this assay, from the lowest: compound 2; then compounds 3 and 1 (each within the scatter of the next).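

In this assay, the advantage of the 1,3,4-thiadiazol-2-yl on this sulfur did not carry over to the larger 5-(pyridin-4-yl)-1,3-thiazol-2-yl, which gave a 7.4-fold higher number from compound 2 to compound 3 (0.87 log units; beyond the scatter) and so gave back most of that advantage. Against the pyridin-2-yl, the same group gave a 1.4-fold lower number from compound 1 to compound 3 (0.16 log units; within the scatter) and this leaves compound 1 and compound 3 indistinguishable, so that of the three groups on this sulfur only the 1,3,4-thiadiazol-2-yl of compound 2 stands apart. No available evidence accounts for this outcome.

Compound 3 changes the five-membered ring and adds the pyridin-4-yl together, so the compounds shown cannot say which of the two matters. On these data alone, how a plain 1,3-thiazol-2-yl, or an amine on the 1,3,4-thiadiazol-2-yl, would read also stays open.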